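Isomeric Oxadiazole Swap at the Thiazole Carboxamide Position

This account rests on a few compounds, and the source may have more. Where it says the series, first, only, none or still open, it means among the compounds named here.

The measured compounds are: compound 1, `Cc1nnc(-c2sc(-c3cccc(F)c3)nc2O)o1`, with 9100 nM in an assay on HEK293 cells for inhibition of transient receptor potential cation channel subfamily M member 8 (Homo sapiens), read by FLIPR, with stated times of 5 min and 3 min; a higher number here means a weaker inhibitor, a lower number a stronger inhibitor; compound 2, `Oc1nc(-c2cccc(F)c2)sc1-c1nn[nH]n1`, whose value in this assay is a limit, > 100000 nM; and compound 3, `CON(C)C(=O)c1sc(-c2cccc(F)c2)nc1O`, with 96 nM in this assay.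

Compound 3 stands lowest of the two numbers shown; the nearest number is that of compound 1, which is a 95-fold lower number from compound 1 to compound 3 (1.98 log units; beyond the scatter) reversed. Compound 2 sits at the limit of this assay (the limit of > 100000 nM in this assay, at which 1 of the 3 values shown sits), so its value is a limit and not a number.

Compound 4, `Cc1nc(-c2sc(-c3cccc(F)c3)nc2O)no1`, differs from compound 3 in one place: 5-methyl-1,2,4-oxadiazol-3-yl in place of methoxy(methyl)carbamoyl on an aromatic carbon. The step that bears on this change is a 95-fold lower number from compound 1 to compound 3 (1.98 log units; beyond the scatter), which exchanged a methyl-oxadiazolyl group for methoxy(methyl)carbamoyl. The move from compound 3 to compound 4 runs the other way, to an isomeric methyl-oxadiazolyl group, so a large rise of roughly that size is expected. For compound 4 the estimate is 6000 nM, between 1500 nM and 30000 nM, a step of a 63-fold higher number from compound 3 to compound 4 (1.80 log units; beyond the scatter).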

Compound 4, half-maximal inhibitory concentration: 1800 nM
Compound 4: middle estimate off by 3.3-fold (0.52 log units), on the high side, and the stated range covers the measured number.
By their numbers in this assay, from the lowest: compound 3; then compound 4; then compound 1. At a limit, above all of these: compound 2.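

In this assay, the two isomeric methyl-oxadiazolyl groups are not interchangeable at this position: the step is a 5.1-fold lower number from compound 1 to compound 4 (0.70 log units; beyond the scatter), modest but beyond the scatter, so the arrangement of the ring atoms alone shifts the number. The 5-methyl-1,2,4-oxadiazol-3-yl group still falls well short of methoxy(methyl)carbamoyl, with a 19-fold higher number from compound 3 to compound 4 (1.27 log units; beyond the scatter), although the two groups have the same count of heavy atoms, so that count alone does not set the number. The step of an at least 55-fold lower number from compound 2 to compound 4 (1.74 log units; beyond the scatter) rests on a limit for compound 2, not a number: the limit of > 100000 nM in this assay, at which 1 of the 4 values shown sits.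

The compounds shown leave open which part of methoxy(methyl)carbamoyl carries its advantage, as a dimethylamide or a carboxylic acid in the same place would help to separate. They also leave open how a 1,3-oxazole or a 1,2,4-triazole would compare with the two oxadiazoles.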